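A few compounds are considered here, and "the series" means these few. Any claim that something is new, unique, unknown or untested is made for them only; others in the source may bear on it.

Compound 1 `COc1cc(O)c(C=O)c2c1[C@H](O)C[C@@H](c1ccccc1)O2`: 130000 nM
Compound 2 `COc1c(C)c(OC)c2c(c1C=O)O[C@H](c1ccccc1)C[C@H]2O`: "not active" (no number reported)
Compound 3 `COc1c(C)c(OC)c2c(c1C)O[C@H](c1ccccc1)C[C@H]2O`: "not active" (no number reported)
Compound 4 `COc1c(C)c(O)c(C=O)c2c1[C@H](O)C[C@@H](c1ccccc1)O2`: not yet measured

In a functional assay on HuCC-A1 cells (Homo sapiens) for cytotoxicity, read by MTT assay (a higher number here means a weaker inhibitor, a lower number a stronger inhibitor), compound 1 gives 130000 nM. Compound 2 has no single number in this assay; it was reported as "not active" (no number reported), so no value can be set beside compound 1 for it. The same holds for compound 3, reported as "not active" (no number reported). Compound 2 therefore stands as one of two entries without a number, and the only measured figure in the set belongs to compound 1.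

The step from compound 2 to compound 4 is a small one: hydrogen in place of methyl on an oxygen on an aromatic ring. Compound 4 then carries the hydroxy group and the aldehyde that compound 1 also carries, and differs from compound 1 only by a methyl on the aromatic ring. For the measured compounds named here, no measured step of this kind exists here, so the size and direction of the change cannot be read from the data; the only anchor is compound 1.

Compound 4 is expected to land near compound 1, with an estimate of 130000 nM and a range from 40000 nM to 400000 nM, because compound 1 gives 130000 nM with the same hydroxy and aldehyde in place.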

Compound 4, half-maximal inhibitory concentration: 143000 nM
Compound 4: middle estimate off by 1.1-fold (0.04 log units), on the low side; the range from low to high includes it.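

Placing a methyl where hydrogen stood on an aromatic carbon gives a 1.1-fold higher number from compound 1 to compound 4 (0.04 log units; within the scatter) in this assay and so the two values cannot be told apart. For the compounds shown here, this is the first sign that this aromatic carbon can carry a methyl with no readable effect on the result. Compound 2, with methoxy where compound 4 has hydroxy, was reported as "not active", whereas compound 4 gives 143000 nM and so the size of that step cannot be read.

No measurement shown here explains these results. Still open, as far as these compounds go, is whether a larger group on the same aromatic carbon, such as an ethyl or an amine, would also leave the value within the scatter.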